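The compounds below may be only part of what the source reports. "The series", "measured", "known", "first", "only" and "open" are said of these compounds alone.

Compound 1 `Nc1ncnc2c1ncn2C[C@@H]1C[C@H](O)c2ccccc21` gives, in an ADME assay on L1210/0 cells (Mus musculus) for cytotoxicity, with a stated time of 48 h (on this read-out lower numbers stand for stronger inhibition and higher numbers for weaker inhibition), a limit rather than a number: > 200000 nM.
Compound 2 `N#CSc1cn([C@H]2C[C@H](O)[C@@H](CO)O2)c(=O)[nH]c1=O` gives in this assay the value 78900 nM.
Compound 3 `O=c1[nH]c(=O)n([C@@H]2CCC[C@H]2CO)cc1I` gives in this assay a limit only: > 200000 nM.

Compound 2 is the only one of the three with a measured number; the other two sit at the limit of > 200000 nM in this assay, at which 2 of the 3 values shown sit. Compound 4 `CC#Cc1cn([C@H]2C[C@H](O)[C@@H](CO)O2)c(=O)[nH]c1=O` differs from compound 2 in one place: prop-1-yn-1-yl in place of cyanosulfanyl on an aromatic carbon. Within the data shown here, no step between measured compounds is available, so the size of the change can only be estimated. The expected step from compound 2 to compound 4 in this assay is a 3.9-fold lower number from compound 2 to compound 4 (0.60 log units; beyond the scatter), a shift toward stronger inhibition that goes beyond the usual scatter. Compound 4 is therefore expected to give about 20000 nM, within a range from 3000 nM to 150000 nM.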

Compound 4, half-maximal inhibitory concentration: > 200000 nM
Compound 4: no number, only a limit; the forecaster's own chance of this, stated with the estimate: 15%; middle value at least 10-fold (1.00 log units) away from the limit.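

Replacing cyanosulfanyl with prop-1-yn-1-yl at this aromatic carbon gives in this assay an at least 2.5-fold higher number from compound 2 to compound 4 (0.40 log units; beyond the scatter) and so moves toward weaker inhibition, the opposite direction to the one expected. Compound 4 gives > 200000 nM as a limit and not a number, so the step has a lower bound only. Compound 4 thereby joins the other compounds held at a limit: the limit of > 200000 nM in this assay, at which 3 of the 4 values shown sit.

As far as these compounds go, how far the number would rise at this position therefore stays unknown. Also open, from the compounds shown here alone, is whether an amine or a longer alkyne chain at this aromatic carbon would give a measurable number.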